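Adding an amino group to compound 2

The source may hold more compounds than are shown below. What is called first, only, known or untested is meant among the compounds shown, and "the series" means these compounds.

Measured in a functional assay on SK-N-SH cells (Homo sapiens) for cytotoxicity, read by MTT assay, with a stated time of 24 h; a lower number here means a stronger inhibitor, a higher number a weaker inhibitor:
- compound 1 `Nc1cccn2cc(Cc3ccccc3)c(=O)nc12`: 116000 nM
- compound 2 `O=c1nc2ccc(Br)cn2cc1Cc1ccccc1`: 137000 nM

Compound 2 stands within the scatter of compound 1, so these two values set no order. Compound 3 `Nc1cc(Br)cn2cc(Cc3ccccc3)c(=O)nc12` is compound 2 with one change: amino in place of hydrogen on an aromatic carbon. The amino group takes the place of hydrogen on an aromatic carbon, ortho to a fused ring and meta to a bromo group.

For the measured compounds named here, no measured pair shows this change alone. Going by the values given here, the only guide in this assay is that compound 1 at 116000 nM and compound 2 at 137000 nM lie close together, so no step beyond the scatter is expected, in either direction. The expected step is a 1.1-fold lower number from compound 2 to compound 3 (0.06 log units; within the scatter). For compound 3 the estimated value is 120000 nM, with an expected range of 60000 nM to 230000 nM.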

Compound 3, half-maximal inhibitory concentration: 149000 nM
Compound 3: middle estimate off by 1.2-fold (0.09 log units), on the low side, and the stated range covers the measured number.
By their numbers in this assay, from the lowest: compounds 1, 2 and 3 (each within the scatter of the next).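

In this assay, amino in place of hydrogen on an aromatic carbon, ortho to a fused ring and meta to a bromo group, gives a 1.1-fold higher number from compound 2 to compound 3 (0.04 log units; within the scatter), so this change, now read directly, sets no order at this position. For the compounds shown here, with the amino group present, adding a bromo group to the core gives a 1.3-fold higher number from compound 1 to compound 3 (0.11 log units; within the scatter), so this second change also stays within the scatter and the two changes together shift no compound clear of the others. Nothing available bears on why these numbers stay so close together.

Going by these compounds, whether this position would answer to a different group, such as a carboxylic acid or a longer chain in place of the amino group, remains open. Also open, on these data alone, is whether a methoxy group in place of the bromo group would move the number beyond the scatter.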